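Cycloalkyl size on the ring nitrogen of a weak series

This account rests on a few compounds, and the source may have more. Where it says the series, first, only, none or still open, it means among the compounds named here.

Compound 1 `Clc1ccccc1Cn1nnc2c(NC3CCC3)nc(-c3ccccc3)nc21` is the weaker of the two measured compounds in an assay on isolated protein for binding affinity to adenosine receptor A1 (Bos taurus) (a lower number here means a stronger inhibitor, a higher number a weaker inhibitor), giving 24000000 nM. Compound 2 `CCCNc1nc(-c2ccccc2)nc2c1nnn2Cc1ccccc1F` gives 3200000 nM in this assay, a lower number than compound 1 by a margin beyond the scatter; the two differ in more than one place, so nothing is drawn from the pair about any single change. Compound 3 `Clc1ccccc1Cn1nnc2c(NC3CCCCC3)nc(-c3ccccc3)nc21` is the next compound to be measured in this assay. It differs from compound 1 as follows: cyclohexyl in place of cyclobutyl on a nitrogen on an aromatic ring. Going by the values given here, no measured pair shows this change alone, so there is no comparable step to rest on. The step from compound 1 to compound 3 in this assay is expected to be modest, most likely towards a lower number, a 2.4-fold lower number from compound 1 to compound 3 (0.38 log units; beyond the scatter), though none beyond the scatter would not surprise. Compound 3 is expected to give about 10000000 nM in this assay, within 2000000 nM to 50000000 nM.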

Compound 3, inhibition constant: 34000000 nM
For compound 3 the middle estimate is 3.4-fold (0.53 log units) below the measured one, and the stated range covers the measured number.
By their numbers in this assay, from the lowest: compound 2; then compounds 1 and 3 (each within the scatter of the next).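

Going by these compounds alone, the only single-place step at this position, read in this assay, is a 1.4-fold higher number from compound 1 to compound 3 (0.15 log units; within the scatter), for cyclohexyl in place of cyclobutyl on a nitrogen on an aromatic ring. Adding to the carbon ring, from four-membered to six-membered, therefore gives no separation between compound 1 and compound 3, and this pair offers no sign that ring size at this nitrogen matters over that span. Nothing available explains why the two rings read alike.

Going by these compounds, whether cyclopentyl, or a longer chain ending in an amine or a carboxylic acid, would move the number beyond the scatter on the core of compound 1 remains open. One step also cannot show whether the same change would read alike on a different core.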